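Swapping the aryl group on the ring nitrogen

A few compounds are considered here, and "the series" means these few. Any claim that something is new, unique, unknown or untested is made for them only; others in the source may bear on it.

For the measured compounds named here, in a functional assay on HL-60 cells (Homo sapiens) for inhibition, read by MTT assay, with a stated time of 72 h (on this read-out higher numbers stand for weaker inhibition and lower numbers for stronger inhibition), compound 3 `Cc1nc(-c2ccccc2)c(C(=O)N2CCN(c3cccc(C)c3C)CC2)o1` gives 35 nM, the lowest of the three numbers measured so far. Compound 1 `Cc1nc(-c2ccccc2)c(C(=O)N2CCN(c3cccc(C(N)=O)c3)CC2)o1` gives 71 nM and compound 2 `Cc1nc(-c2ccccc2)c(C(=O)N2CCN(c3c(C)cccc3C)CC2)o1` gives 146 nM. The two measured steps were a 2.0-fold lower number from compound 1 to compound 3 (0.31 log units; beyond the scatter) and a 4.2-fold lower number from compound 2 to compound 3 (0.62 log units; beyond the scatter). Compound 4 `Cc1nc(-c2ccccc2)c(C(=O)N2CCN(c3cccc(F)c3)CC2)o1` has not yet been measured; it differs from compound 3 as 3-fluorophenyl in place of 2,3-dimethylphenyl on an amine nitrogen in a ring. Going by the values given here, no measured step involves 3-fluorophenyl, so the expectation rests only on the observation that each departure from 2,3-dimethylphenyl gave a higher number, with no way to tell how closely 3-fluorophenyl will follow. Compound 4 is therefore expected to show a modest rise, a 2.0-fold higher number from compound 3 to compound 4 (0.30 log units; within the scatter). The estimate for compound 4 is 70 nM, with a range from 30 nM to 170 nM.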

Compound 4, half-maximal inhibitory concentration: 45 nM
Compound 4: middle estimate off by 1.6-fold (0.19 log units), on the high side, and the stated range covers the measured number.
By their numbers in this assay, from the lowest: compounds 3, 4 and 1 (each within the scatter of the next, the first and the last beyond it); then compound 2.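

In this assay, 3-fluorophenyl and 2,3-dimethylphenyl on the ring nitrogen cannot be told apart (a 1.3-fold higher number from compound 3 to compound 4 (0.11 log units; within the scatter)). Fluoro in place of carbamoyl on the aromatic carbon also stays within the usual spread (a 1.6-fold lower number from compound 1 to compound 4 (0.20 log units; within the scatter)), so three quite different aryl groups give similar numbers here. Only 2,6-dimethylphenyl stands apart (a 3.2-fold lower number from compound 2 to compound 4 (0.51 log units; beyond the scatter)). Going by these compounds, whether an aryl group carrying an amine or a carboxylic acid would stay in this range remains open. Nothing available explains why 2,6-dimethylphenyl differs.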